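Benzyl to phenyl on the amino nitrogen of compound 3

A few compounds are considered here, and "the series" means these few. Any claim that something is new, unique, unknown or untested is made for them only; others in the source may bear on it.

Compound 1, `Cc1ccc(Nc2ncc(Cl)c(Nc3ccccc3C)n2)cc1`: > 100000 nM
Compound 2, `Cc1ccccc1Nc1nc(Nc2ccccn2)ncc1Cl`: 11200 nM
Compound 3, `COc1cccc(CNc2nc(Nc3ccc(N4CCN(C)CC4)cn3)ncc2Cl)c1`: 20300 nM

In a functional assay on MDA-MB-231 cells (Homo sapiens) for inhibition, read by CCK-8 assay, with a stated time of 48 h (a higher number here means a weaker inhibitor of growth, a lower number a stronger inhibitor of growth), compound 1 gives > 100000 nM, which is a limit of the assay and not a number. Compound 2 gives 11200 nM and compound 3 gives 20300 nM; compound 3 thus holds the highest of the two numbers, with compound 2 nearest and within the scatter of it.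

Compound 4, `COc1cccc(Nc2nc(Nc3ccc(N4CCN(C)CC4)cn3)ncc2Cl)c1`, is not yet measured in this assay. It differs from compound 3 in one place: 3-methoxyphenyl in place of 3-methoxybenzyl on a nitrogen on an aromatic ring.

Among the compounds with values here, the only measured step, an at least 8.9-fold lower number from compound 1 to compound 2 (0.95 log units; beyond the scatter), exchanges one aromatic group for another on the nitrogen and does not remove a benzyl linker, so it does not bear directly on the change from compound 3 to compound 4. With nothing measured that matches this change, compound 4 is expected to stay within the scatter of compound 3, a step of a 1.4-fold lower number from compound 3 to compound 4 (0.13 log units; within the scatter). Compound 4 is therefore estimated at 15000 nM, in the range 4000 nM to 60000 nM.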

Compound 4, concentration for 50% growth inhibition: 8510 nM
The estimate for compound 4 lay 1.8-fold (0.25 log units) above the measured number, within the range that was stated.
By their numbers in this assay, from the lowest: compounds 4, 2 and 3 (each within the scatter of the next, the first and the last beyond it). At a limit, above all of these: compound 1.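

In this assay, a 2.4-fold lower number from compound 3 to compound 4 (0.38 log units; beyond the scatter), a modest change, but one that lies beyond the scatter. This is the first step shown on the nitrogen that carries the 3-methoxybenzyl group, since the earlier step concerned an aromatic group on a different nitrogen, and it shows that exchanging benzyl for phenyl here moves the number even with the methoxy group and the rest of the molecule kept the same. Nothing given here accounts for this change.

The compounds shown leave open how a longer chain, such as 2-phenylethyl, or a saturated ring, such as cyclohexyl, would read on this nitrogen. They also leave open whether the 3-methoxy group contributes at all, as a comparison with a hydroxy group, a fluorine or an unsubstituted phenyl would show.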